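Amino to carbamoyl at the halogen position of the indole series

The source may report more compounds than this note shows. Statements on the series, on what has been measured and on what is new or still open speak of the compounds shown alone.

Measured so far:
compound 1 `CN1CCCN(CCn2ccc3ccc(Br)cc32)CC1` gives 93%
compound 2 `CN1CCCN(CCn2ccc3ccc(Cl)cc32)CC1` gives 85%
compound 3 `CN1CCCN(CCn2ccc3ccc(N)cc32)CC1` gives 0%

All three share one core and differ only in a single substituent on the six-membered aromatic ring. In an assay on HEK293 cells for binding affinity to 5-hydroxytryptamine receptor 7 (Homo sapiens), read by radioligand binding, tested at 1 uM (a higher number here means more inhibition at the concentration tested (going by the name of the read-out), a lower number less inhibition), compound 3 stands lowest of the three. Its nearest neighbour is compound 2, reached by a number 85 percentage points lower from compound 2 to compound 3 (beyond the scatter); compound 1 lies furthest, with a number 93 percentage points lower from compound 1 to compound 3 (beyond the scatter). Between the two halogen compounds the change is a number 8 percentage points lower from compound 1 to compound 2 (within the scatter), so bromo and chloro behave alike here while amino wipes out the inhibition.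

Compound 4 `CN1CCCN(CCn2ccc3ccc(C(N)=O)cc32)CC1` has not been measured. Its change from compound 3 is carbamoyl in place of amino on an aromatic carbon.

Within the data shown here, no measured step involves carbamoyl, so the two large steps from the halogens to amino are the only ones that bear on this change, and they bear on it only indirectly: they show that the substituent at this place decides whether inhibition is seen at all. Carbamoyl is neither a halogen nor amino, so a step upward in this assay from compound 3 is plausible but its size is unknown; a partial recovery is expected rather than a return to the halogen level.

The estimate for compound 4 is 25%, within 0% to 65%, which means an expected step of a number 25 percentage points higher from compound 3 to compound 4 (beyond the scatter).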

Compound 4, a percentage reported as inhibition, at one concentration (the size of the read-out at that concentration, not a potency): 33%
For compound 4 the middle estimate is 8 percentage points below the measured one; the range from low to high includes it.
By their numbers in this assay, from the lowest: compound 3; then compound 4; then compounds 2 and 1 (each within the scatter of the next).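

In this assay this position no longer reads as a simple split between halogens that inhibit and a non-halogen that does not: a number 33 percentage points higher from compound 3 to compound 4 (beyond the scatter), so a non-halogen group can restore part of the inhibition, and since amino and carbamoyl carry the same hydrogen-bond donor and acceptor counts, those counts alone do not separate the two compounds. The recovery remains partial, with a number 52 percentage points lower from compound 2 to compound 4 (beyond the scatter) and a number 60 percentage points lower from compound 1 to compound 4 (beyond the scatter), which places carbamoyl on an intermediate level of its own, clearly apart from amino on one side and from both halogens on the other. No measurement at hand gives a reason for this order among the substituents.

Still open, from the compounds shown here alone, is which part of carbamoyl carries the gain over amino, a question that a nitrile, a carboxylic acid, a methyl ester or a methyl-substituted amide at the same place could address. Also open is whether fluoro or methoxy would stand with the halogens or with carbamoyl, and since each value comes from a single concentration, the series as shown gives no potencies.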